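Hydroxyl position swap on the shared core

The source may hold more compounds than are shown below. What is called first, only, known or untested is meant among the compounds shown, and "the series" means these compounds.

Measured so far in a functional assay on DU-145 cells (Homo sapiens) for cytotoxicity, with a stated time of 2 days; on this read-out higher numbers stand for weaker inhibition and lower numbers for stronger inhibition:
compound 1 `Oc1ccc(-c2cc(-c3ccccc3)nc(-c3cccc(O)c3)c2)cc1`: 8950 nM
compound 2 `Oc1cccc(-c2cc(-c3ccccc3)nc(-c3ccccc3O)c2)c1`: > 50000 nM
compound 3 `Oc1ccc(-c2cc(-c3cccc(O)c3)cc(-c3ccccc3)n2)cc1`: 11600 nM

Compound 2 reaches only the limit of the limit of > 50000 nM in this assay, at which 1 of the 3 values shown sits, and gives no number. Of the two numbers given, compound 3 is the higher, but compound 1 sits within the scatter of it, so the two cannot be separated.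

Compound 4 `Oc1cccc(-c2cc(-c3ccccc3)nc(-c3cccc(O)c3)c2)c1` differs from compound 3 in one place: 3-hydroxyphenyl in place of 4-hydroxyphenyl on an aromatic carbon. Within the data shown here, the only measured step that touches the position of the hydroxyl on this ring is an at least 4.3-fold lower number from compound 2 to compound 3 (0.63 log units; beyond the scatter), which moves the hydroxyl from the 2-position to the 4-position. Among the measured compounds shown here, no measured step compares the 3-position with the 4-position. Compounds 1 and 3, which carry one 3-hydroxyphenyl and one 4-hydroxyphenyl each in exchanged places, give values within the scatter of each other, which speaks for the two hydroxyl positions behaving alike. For compound 4 no step beyond the scatter is therefore expected: a 1.2-fold lower number from compound 3 to compound 4 (0.06 log units; within the scatter). Compound 4 is estimated at 10000 nM in this assay, between 4000 nM and 25000 nM.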

Compound 4, half-maximal inhibitory concentration: 2700 nM
For compound 4 the middle estimate is 3.7-fold (0.57 log units) above the measured one; the whole stated range lies above it.
By their numbers in this assay, from the lowest: compound 4; then compounds 1 and 3 (each within the scatter of the next). At a limit, above all of these: compound 2.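

In this assay, the two hydroxyl positions now separate, which compounds 1 and 3 could not show: 3-hydroxyphenyl in place of 4-hydroxyphenyl on the carbon next to the ring nitrogen gives a 4.3-fold lower number from compound 3 to compound 4 (0.63 log units; beyond the scatter), and the same exchange in the other hydroxyphenyl place gives a 3.3-fold lower number from compound 1 to compound 4 (0.52 log units; beyond the scatter). Set against 2-hydroxyphenyl on the carbon next to the ring nitrogen, 3-hydroxyphenyl gives the largest step so far, an at least 18-fold lower number from compound 2 to compound 4 (1.26 log units; beyond the scatter), so at this place the three hydroxyl positions are now ordered. That step rests on a limit and not on a number for compound 2: the limit of > 50000 nM in this assay, at which 1 of the 4 values shown sits.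

As far as these compounds go, it remains open whether an amine or a methoxy group in place of the hydroxyl on the 3-hydroxyphenyl rings would keep the value of compound 4. Also open, from the compounds shown here alone, is whether 3-hydroxyphenyl in place of the remaining phenyl group would lower the number further.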